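The compounds below may be only part of what the source reports. "The series", "measured", "known", "first", "only" and "open" are said of these compounds alone.

Measured compounds in a functional assay on A549 cells (Homo sapiens) for inhibition, read by CCK-8 assay, with a stated time of 72 h, tested at 10 uM; on this read-out lower numbers stand for a weaker effect and higher numbers for a stronger effect at the one concentration tested:

- compound 1, `CN(C)C(=O)c1cc2cnc(Nc3ccc(C(=O)NCCCCCN=C=S)cc3)nc2n1C1CCCC1`: 100%
- compound 2, `CN(C)C(=O)c1cc2cnc(Nc3ccc(C(=O)NCCCCCCCN=C=S)cc3)nc2n1C1CCCC1`: 101%

Compound 2 stands alongside compound 1 on this read-out; the two values lie within the scatter of each other, so neither can be set apart from the other. Going by the values given here, the single step between them, a number 1 percentage points higher from compound 1 to compound 2 (within the scatter), shows that lengthening the chain bearing the isothiocyanate from a group of 3 heavy atoms to a group of 5 heavy atoms leaves the read-out where it was, with both compounds at essentially complete inhibition at the one concentration tested.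

Compound 3, `CN(C)C(=O)c1cc2cnc(Nc3ccc(C(=O)NCCCCCCCN=C=S)cc3F)nc2n1C1CCCC1`, is the next member. It differs from compound 2 by fluoro in place of hydrogen on an aromatic carbon. Among the compounds with values here, no measured step touches an aromatic carbon of the ring that carries the amide, so the effect of this change has no direct precedent here; the only step known, from compound 1 to compound 2, concerns the chain and was within the scatter. Given that compound 2 already sits at full inhibition, the expected step is a number 3 percentage points lower from compound 2 to compound 3 (within the scatter), that is, none beyond the scatter. Compound 3 is therefore estimated at 98%, with a range from 85% to 103%.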

Compound 3, a percentage reported as inhibition, at one concentration (the size of the read-out at that concentration, not a potency): 12.7%
Compound 3: the middle estimate sits 85.3 percentage points above what was measured, outside the stated range (below it).
By their numbers in this assay, from the lowest: compound 3; then compounds 1 and 2 (each within the scatter of the next).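

Fluoro in place of hydrogen on this aromatic carbon, ortho to a large group and meta to a large group, gives a number 88.3 percentage points lower from compound 2 to compound 3 (beyond the scatter) in this assay and is the first change in the series to move the read-out. The chain change, by contrast, gave a number 1 percentage points higher from compound 1 to compound 2 (within the scatter), so this read-out is far more sensitive to a single fluorine at this position than to the chain lengthening, at least in the compounds compared here. No measurement at hand accounts for the size of this step.

The compounds shown leave open whether the loss is specific to fluoro or would also follow from chloro, methyl or methoxy at the same carbon, and whether fluoro on the other carbons of this ring would behave the same way. They also leave open whether the same fluoro change would have a similar effect with the shorter chain of compound 1 , and, with only one concentration tested, how the step would translate into a difference in potency.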